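Replacing the oxygen substituent of compound 1

A few compounds are considered here, and "the series" means these few. Any claim that something is new, unique, unknown or untested is made for them only; others in the source may bear on it.

Measured in a functional assay on HL-60 cells (Homo sapiens) for inhibition, read by CCK-8 assay, with a stated time of 48 h; on this read-out higher numbers stand for weaker inhibition and lower numbers for stronger inhibition:
- compound 1 `O=C(NCCNS(=O)(=O)c1ccc(-c2ccccc2O[C@H]2CC[C@H](O)CC2)s1)Nc1cc(C(F)(F)F)cc(C(F)(F)F)c1`: 7100 nM
- compound 2 `Cc1ccc(-c2ccsc2S(=O)(=O)NCCNC(=S)Nc2ccc([N+](=O)[O-])cc2)c(Oc2ccc(O)c(O)c2)c1`: 2900 nM
- compound 3 `O=[N+]([O-])c1cccc(NC(=S)NCCNS(=O)(=O)c2ccc(-c3ccccc3OCc3cccc(O)c3)s2)c1`: 11400 nM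

Compound 1 at 7100 nM lies within the scatter of compound 3 at 11400 nM. Compound 2 at 2900 nM has a lower number than compound 1, and that gap lies beyond the scatter.

The next compound is compound 4 `O=C(NCCNS(=O)(=O)c1ccc(-c2ccccc2Oc2ccc([N+](=O)[O-])c([N+](=O)[O-])c2)s1)Nc1cc(C(F)(F)F)cc(C(F)(F)F)c1`, which keeps the rest of compound 1 and carries 3,4-dinitrophenyl in place of 4-hydroxycyclohexyl on an oxygen on an aromatic ring.

Going by the values given here, no measured pair isolates this change, so the expectation is weakly grounded. Compound 2, at 2900 nM, also has an aromatic ring on that oxygen, but it differs from compound 1 in more than one place. A small move toward a lower number in this assay is therefore expected, not clearly beyond the scatter. The estimated step is a 1.8-fold lower number from compound 1 to compound 4 (0.25 log units; within the scatter). For compound 4 the expected value is 4000 nM, with an estimated range of 1500 nM to 11000 nM.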

Compound 4, half-maximal inhibitory concentration: 1900 nM
Compound 4: middle estimate off by 2.1-fold (0.32 log units), on the high side; the range from low to high includes it.
By their numbers in this assay, from the lowest: compounds 4 and 2 (each within the scatter of the next); then compounds 1 and 3 (each within the scatter of the next).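

In this assay, going by these compounds alone, the oxygen substituent of compound 1 is the first position with a single-place comparison, and the step is beyond the scatter: a 3.7-fold lower number from compound 1 to compound 4 (0.57 log units; beyond the scatter). The position therefore tolerates a larger aromatic group in place of a non-aromatic ring, and the 3,4-dinitrophenyl group reaches this level of inhibition with no hydrogen-bond donor and no defined stereocentres in that substituent. No measurement available here explains the step.

The change replaces the ring, the hydroxyl and the stereocentres together, so what each contributes remains unresolved. An unsubstituted phenyl, or a phenyl carrying an amine or a carboxylic acid in place of the nitro groups, would show whether the aromatic ring alone accounts for the step.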